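Methylsulfanyl for cyano on the core of compound 3

The source may hold more compounds than are shown below. What is called first, only, known or untested is meant among the compounds shown, and "the series" means these compounds.

Compound 3 `CN1CCCC(NC(=O)c2ccc(C(F)(F)F)cc2C#N)(c2ccccc2)C1` stands at the lower edge of what an assay on cells for inhibition of sodium- and chloride-dependent glycine transporter 1 (Homo sapiens) (a higher number here means that more compound is needed for the effect, a lower number that less compound is needed), can report. In this assay compound 3 gives only a limit, > 10000 nM, which is a boundary of the assay and not a number, as noted in the limit of > 10000 nM in this assay, at which 1 of the 3 values shown sits. The closest measured neighbour is compound 2 `COc1cc(C(F)(F)F)ccc1C(=O)NC1(c2ccccc2)CCCN(C)C1`, which in this assay gives 4800 nM. The step from compound 2 to compound 3 amounts to an at least 2.0-fold higher number from compound 2 to compound 3 (0.31 log units; beyond the scatter). Compound 1 `CCN1CCCC(NC(=O)c2c(OC)cc(C(F)(F)F)cc2C(F)(F)F)(c2ccccc2)C1`, with a different pattern on the aromatic ring and on the amine, gives 230 nM in this assay.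

The unmeasured compound 4 `CSc1cc(C(F)(F)F)ccc1C(=O)NC1(c2ccccc2)CCCN(C)C1` differs from compound 3 by methylsulfanyl in place of cyano on an aromatic carbon. Among the compounds with values here, the only measured step that bears on this change is the one from compound 2 to compound 3, in which a methoxy group left and a cyano group entered at the same carbon; it went beyond the scatter. Compound 4 reverses the cyano part of that change and puts a methylsulfanyl group in its place, so the expected direction is back toward the number of compound 2, by a step estimated as an at least 2.5-fold lower number from compound 3 to compound 4 (0.39 log units; beyond the scatter). Compound 4 is therefore expected to give about 4000 nM in this assay, within a range from 1000 nM to 15000 nM.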

Compound 4, half-maximal effective concentration: 67 nM
Estimate against measurement, compound 4: 60-fold (1.78 log units) above; the measured number lies below the stated range.
By their numbers in this assay, from the lowest: compound 4; then compound 1; then compound 2. At a limit, above all of these: compound 3.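

The step from compound 2 to compound 3 showed only that cyano at this aromatic carbon, ortho to a large group and meta to a trifluoromethyl group, fared worse than methoxy in this assay, whereas methylsulfanyl in place of methoxy gives a 72-fold lower number from compound 2 to compound 4 (1.86 log units; beyond the scatter). The methoxy group of compound 2 is therefore far from the best group shown at this carbon, and an exchange at this one place on the shared core can move the number by a large step. Methylsulfanyl in place of cyano gives an at least 140-fold lower number from compound 3 to compound 4 (2.17 log units; beyond the scatter), and that size is only a bound, since compound 3 stands at a limit of the assay and not at a number: the limit of > 10000 nM in this assay, at which 1 of the 4 values shown sits.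

The compounds shown leave open whether a longer chain on the sulfur, such as ethylsulfanyl, or a chlorine atom at this carbon would hold the number of compound 4, 67 nM. They also hold no measured property that accounts for the step, and they do not tell whether the gain from methylsulfanyl carries over to the core of compound 1.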